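The compounds below may be only part of what the source reports. "The series", "measured", "known", "first", "only" and "open" are said of these compounds alone.

Compound 1 `CCc1ccc(-c2cc(-c3cn([C@H]4C[C@H](OC(C)=O)[C@@H](COC(C)=O)O4)c(=O)[nH]c3=O)on2)cc1` gives 92.2% in a functional assay on HCT-15 cells (Homo sapiens) for cytotoxicity, read by sulforhodamine B assay, tested at 10 uM; on this read-out higher numbers stand for more inhibition at the one concentration tested (going by the name of the read-out) and lower numbers for less inhibition; compound 2 `CC(=O)OC[C@H]1O[C@@H](n2cc(-c3cc(-c4ccc(C(C)C)cc4)no3)c(=O)[nH]c2=O)C[C@@H]1OC(C)=O` gives 80.9%.

Compound 2 stands lowest of the two numbers in this assay. Compound 3 `CCCCc1ccc(-c2cc(-c3cn([C@H]4C[C@H](OC(C)=O)[C@@H](COC(C)=O)O4)c(=O)[nH]c3=O)on2)cc1` differs from it by butyl in place of isopropyl on an aromatic carbon. Among the compounds with values here, the only measured step, a number 11.3 percentage points lower from compound 1 to compound 2 (beyond the scatter), altered the same chain on the same aromatic carbon and lowered inhibition modestly, but it does not test a longer unbranched chain, so its bearing is indirect and the direction is uncertain. Only a small shift in this assay is expected, a number 3.1 percentage points higher from compound 2 to compound 3 (within the scatter). Compound 3 is estimated at 84%, between 70% and 95%.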

Compound 3, a percentage reported as inhibition, at one concentration (the size of the read-out at that concentration, not a potency): 71.4%
Compound 3: middle estimate off by 12.6 percentage points, on the high side; the range from low to high includes it.
By their numbers in this assay, from the lowest: compounds 3 and 2 (each within the scatter of the next); then compound 1.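

In this assay the change from isopropyl to butyl on this aromatic carbon gives a number 9.5 percentage points lower from compound 2 to compound 3 (within the scatter) and so cannot separate the branched chain from the longer unbranched one. Lengthening the unbranched chain from ethyl to butyl does register, with a number 20.8 percentage points lower from compound 1 to compound 3 (beyond the scatter) and compound 1 keeping the highest number of the three. Nothing measured here explains why the longer chain gives less inhibition.

Still open, on these data alone, is whether a shorter methyl group would match ethyl, or a longer hexyl chain would lower the number further. An amine at this position also remains an untested kind of change in the compounds shown.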